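A few compounds are considered here, and "the series" means these few. Any claim that something is new, unique, unknown or untested is made for them only; others in the source may bear on it.

Measured so far in a functional assay on HCT-116 cells (Homo sapiens) for inhibition, read by sulforhodamine B assay, with a stated time of 48 h, tested at 10 uM; a lower number here means less inhibition of growth, a higher number more inhibition of growth at the concentration tested:
compound 1 `CC(=O)c1ccc(Nc2ccnc(SCC(=O)c3ccc(Br)cc3)n2)cc1` gives 10%
compound 2 `CC(=O)c1cccc(Nc2ccnc(SCC(=O)c3ccc(-c4ccccc4)cc3)n2)c1` gives 14%
compound 3 `COc1ccc(C(=O)CSc2nccc(Nc3cccc(C(C)=O)c3)n2)cc1` gives 23%

Compound 2 holds the second highest of the three numbers; compound 1 sits closest, and compound 3 is furthest away, with a number 9 percentage points higher from compound 2 to compound 3 (within the scatter), so all three lie within the usual scatter of one another.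

Compound 4 `CC(=O)c1ccc(Nc2ccnc(SCC(=O)c3ccc(-c4ccccc4)cc3)n2)cc1` is not yet measured. It differs from compound 2 by 4-acetylphenyl in place of 3-acetylphenyl on a nitrogen on an aromatic ring. For the measured compounds named here, no measured step isolates this change: compound 1 also carries the 4-acetylphenyl group but differs from compound 2 in a second place as well, and its value and that of compound 2 are within the scatter. Going by the values given here, the only measured step, from compound 2 to compound 3, concerns a different part of the molecule. For compound 4 the step is therefore expected to stay within the scatter, a number 2 percentage points lower from compound 2 to compound 4 (within the scatter), and compound 4 is estimated at 12%, between 2% and 24%.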

Compound 4, percent growth inhibition at one concentration: 42%
The estimate for compound 4 lay 30 percentage points below the measured number, and the stated range ends below it.
By their numbers in this assay, from the lowest: compounds 1, 2 and 3 (each within the scatter of the next, the first and the last beyond it); then compound 4.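

In this assay, 4-acetylphenyl in place of 3-acetylphenyl on the nitrogen gives a number 28 percentage points higher from compound 2 to compound 4 (beyond the scatter) and shows that the placing of the acetyl counts when phenyl is present on the other ring. For the compounds shown here, with 4-acetylphenyl held, phenyl in place of bromo gives a number 32 percentage points higher from compound 1 to compound 4 (beyond the scatter) and shows that this aromatic carbon counts too, which the one earlier step, within the scatter, did not reveal. Nothing here gives a reason for either step.

Open, from the compounds shown here alone, is whether methoxy, carried by compound 3 with 3-acetylphenyl, also gains from 4-acetylphenyl, and whether an amine or a carboxylic acid in place of the acetyl keeps the gain.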